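Replacing a Cyclopropyl Ring with a Methoxyethyl Chain

The source may report more compounds than this note shows. Statements on the series, on what has been measured and on what is new or still open speak of the compounds shown alone.

Of the compounds shown here, three built on one shared core have been tested in an in vitro ADME assay on microsomes from liver (Mus musculus) for metabolic stability; a lower number here means slower removal, a higher number faster removal of the compound. Compound 1 `Cc1cc(Nc2ccc(C(F)(F)F)cc2)n2nc(C3CC3)nc2n1` gives 8.6 mL.min-1.g-1 in this assay. Compound 3 `Cc1cc(Nc2ccc(S(F)(F)(F)(F)F)cc2)n2nc(C(C)(F)F)nc2n1` gives 8.1 mL.min-1.g-1 in this assay, a number so close to that of compound 1 that the two cannot be told apart. Compound 2 `Cc1cc(Nc2ccc(Cl)cc2)n2nc(C(C)C)nc2n1` gives 158 mL.min-1.g-1 in this assay, a much higher number than that of compound 1, so compound 1 belongs to the slowly cleared end of this small set.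

Compound 4 `COCCc1nc2nc(C)cc(Nc3ccc(C(F)(F)F)cc3)n2n1` has not yet been measured. It differs from compound 1 in one place: 2-methoxyethyl in place of cyclopropyl on an aromatic carbon. Among the compounds with values here, no measured pair in this set differs in only this way, so the step can be judged only from the numbers at hand and the change itself. The expected step is a 3.5-fold higher number from compound 1 to compound 4 (0.54 log units; beyond the scatter), a moderate rise in clearance, beyond the usual scatter. Compound 4 is therefore estimated at 30 mL.min-1.g-1, with a likely range from 10 mL.min-1.g-1 to 90 mL.min-1.g-1.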

Compound 4, intrinsic clearance in microsomes: 14.3 mL.min-1.g-1
Compound 4: middle estimate off by 2.1-fold (0.32 log units), on the high side; the range from low to high includes it.
By their numbers in this assay, from the lowest: compounds 3, 1 and 4 (each within the scatter of the next); then compound 2.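

In this assay, within the data shown here, putting 2-methoxyethyl in place of cyclopropyl on this aromatic carbon gives a 1.7-fold higher number from compound 1 to compound 4 (0.22 log units; within the scatter) as the only step read so far, so the two compounds cannot be told apart. This first one-place comparison in the set shows that, on the core of compound 1, a three-membered ring of carbon only can give way to an open chain holding an oxygen with no change beyond the usual scatter. Nothing measured here explains this result.

A single pair cannot tell whether the same swap would hold with another group on the aniline ring, such as the chlorine of compound 2. On these data alone, how an amine, a carboxylic acid or a longer ether chain would fare at this position also stays open.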